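Acetylating the Thiol of a Weak Metalloproteinase Inhibitor

The compounds below may be only part of what the source reports. "The series", "measured", "known", "first", "only" and "open" are said of these compounds alone.

Compound 2 `C=C[C@@H]1OC(c2ccc(Br)cc2)=N[C@H]1S` stands at a limit: in an assay on isolated protein for inhibition of matrix metalloproteinase-9 (Homo sapiens) (on this read-out higher numbers stand for weaker inhibition and lower numbers for stronger inhibition), compound 2 gives > 100000 nM, a limit of the assay and not a number. Its companion compound 1 `C=C[C@@H]1OC(c2ccc(Cl)cc2)=N[C@H]1S` likewise reaches only a limit, giving > 100000 nM in this assay. The step that the two limits leave unreadable from compound 1 to compound 2 is therefore unreadable, and both values sit at the limit of > 100000 nM in this assay, at which 2 of the 2 values shown sit. Compound 3 `C=C[C@@H]1OC(c2ccc(Br)cc2)=N[C@H]1SC(C)=O` differs from compound 2 by acetyl in place of hydrogen on a sulfur. Among the compounds with values here, no measured step resembles this change, so nothing supports expecting a move beyond the scatter in this assay. For compound 3 the estimate is 100000 nM, with a range from 10000 nM to 1000000 nM. For compound 3 this means an expected step of a number no higher from compound 2 to compound 3 (the limit leaves the size open).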

Compound 3, inhibition constant: 88000 nM
For compound 3 the middle estimate is 1.1-fold (0.06 log units) above the measured one; measured number inside the range.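

In this assay, acetyl in place of hydrogen on the sulfur gives an at least 1.1-fold lower number from compound 2 to compound 3 (0.05 log units; that floor lies within the scatter). This makes compound 3 the only compound shown with a readable number, and it gives this position its first step with a floor, although the step between the two earlier compounds still cannot be read. Since that floor lies within the scatter, the change is not shown to shift inhibition, and the true size of the step stays open.

As far as these compounds go, it also remains open whether acetyl on the sulfur of compound 1 would behave alike. Nor do the compounds shown tell how a longer chain or a carboxylic acid on this sulfur would read.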